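Swapping the five-membered ring on the chlorophenyl arm

This account rests on a few compounds, and the source may have more. Where it says the series, first, only, none or still open, it means among the compounds named here.

Two compounds share one core. Compound 1 `CN1CCN(CCCS(=O)(=O)c2ccc3nc(NC(=O)NC(=O)c4cc(-n5cccn5)ccc4Cl)sc3c2)CC1` carries a 1H-pyrazol-1-yl group, and in a physicochemical assay for lipophilicity (a lower number here means a more polar compound, a higher number a more lipophilic compound), compound 1 gives 2. Among the compounds with values here, compound 2 `CN1CCN(CCCS(=O)(=O)c2ccc3nc(NC(=O)NC(=O)c4cc(N5CCCC5)ccc4Cl)sc3c2)CC1` carries pyrrolidin-1-yl instead, and in this assay compound 2 gives 3.1, the higher of the two numbers; the single measured step, a number 1.10 log units higher from compound 1 to compound 2 (beyond the scatter), is the only guide. Compound 3 `Cc1ccn(-c2ccc(Cl)c(C(=O)NC(=O)Nc3nc4ccc(S(=O)(=O)CCCN5CCN(C)CC5)cc4s3)c2)n1` differs from compound 2 by 3-methyl-1H-pyrazol-1-yl in place of pyrrolidin-1-yl on an aromatic carbon. This largely reverses that step, so a drop of about a number 0.70 log units lower from compound 2 to compound 3 (beyond the scatter) is expected, smaller than the full step because compound 1 gives 2 without the methyl. Compound 3 is estimated at 2.4, ranging from 2 to 2.9.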

Compound 3, distribution coefficient: 2.6
The estimate for compound 3 lay 0.20 log units below the measured number; measured number inside the range.
By their numbers in this assay, from the lowest: compound 1; then compound 3; then compound 2.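

Adding a single methyl to the pyrazole ring at this position is enough to shift the reading in this assay, with a number 0.60 log units higher from compound 1 to compound 3 (beyond the scatter). The methylated ring still does not match pyrrolidin-1-yl, with a number 0.50 log units lower from compound 2 to compound 3 (beyond the scatter), so compound 3 falls between the two earlier compounds. Nothing available here explains these shifts.

From the compounds shown here alone, it remains open whether the methyl would produce a similar step elsewhere on the pyrazole ring. Also unknown is where an ethyl group on that ring, or a morpholine ring in its place, would fall.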